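The source may hold more compounds than are shown below. What is called first, only, known or untested is meant among the compounds shown, and "the series" means these compounds.

Compound 1 `c1ccc(Cn2cc(Cc3nnc(-c4ccccc4)c(-c4ccccc4)n3)nn2)cc1`: 15600 nM in a functional assay on PC-3 cells (Homo sapiens) for antiproliferative activity, read by MTT assay, with a stated time of 48 h; a higher number here means a weaker inhibitor, a lower number a stronger inhibitor
Compound 2 `Fc1ccc(Cn2cc(CSc3nnc(-c4ccccc4)c(-c4ccccc4)n3)nn2)cc1`: 10600 nM in this assay

Both compounds share the same core, and compound 2 sits alongside compound 1, the gap between their numbers lying within the usual scatter. Compound 3 `NS(=O)(=O)c1ccc(-n2cc(CSc3nnc(-c4ccccc4)c(-c4ccccc4)n3)nn2)cc1` carries 4-sulfamoylphenyl in place of 4-fluorobenzyl on an aromatic nitrogen. Within the data shown here, no measured pair shows what such a change does, so the expected step is none beyond the scatter. The step is estimated as a 1.1-fold higher number from compound 2 to compound 3 (0.05 log units; within the scatter). In this assay compound 3 is expected to give 12000 nM, within a range from 4000 nM to 36000 nM.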

Compound 3, half-maximal inhibitory concentration: > 100000 nM
Compound 3: no number, only a limit; the forecaster's own chance of this, stated with the estimate: 10%; at least 8.3-fold (0.92 log units) between middle value and limit.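

Replacing 4-fluorobenzyl with 4-sulfamoylphenyl on this aromatic nitrogen gives an at least 9.4-fold higher number from compound 2 to compound 3 (0.97 log units; beyond the scatter) in this assay, so this position does not accept every group alike. Compound 3 gives > 100000 nM, which is a limit of the assay and not a number. The true size of the step therefore stays unknown: the limit of > 100000 nM in this assay, at which 1 of the 3 values shown sits.

This single step changes two things at once, the sulfonamide group and the loss of the benzyl carbon. A plain phenyl or a 4-sulfamoylbenzyl group on the same nitrogen would tell these two changes apart.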